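Pyridin-3-yl in place of pyridin-2-yl: series notes

The compounds below may be only part of what the source reports. "The series", "measured", "known", "first", "only" and "open" are said of these compounds alone.

In a physicochemical assay for solubility, at pH 7 (on this read-out higher numbers stand for higher solubility and lower numbers for lower solubility), compound 1 (`O=C(Nc1ncc(Cc2ccccn2)s1)C1CCCCC1`) gives 340 ug/mL, the highest of the three numbers and beyond the scatter of the other two. Compound 3 (`O=C(Nc1ncc(Cc2ccnc3ccccc23)s1)C1CCCCC1`) is nearest at 70 ug/mL, and compound 2 (`O=C(CCC1CCCCC1)Nc1ncc(Cc2ccccn2)s1`) is furthest at 40 ug/mL. Compound 4 (`O=C(Nc1ncc(Cc2cccnc2)s1)C1CCCCC1`) carries pyridin-3-yl in place of pyridin-2-yl on a saturated chain carbon bound to an aromatic carbon. Going by the values given here, no measured pair isolates this change, so the expectation rests on compound 1 at 340 ug/mL, which has the same atoms joined differently. In this assay, the expected step is small, a 1.4-fold lower number from compound 1 to compound 4 (0.13 log units; within the scatter), and within the scatter. For compound 4 the estimated value is 250 ug/mL, with an expected range of 100 ug/mL to 600 ug/mL.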

Compound 4, solubility: 340 ug/mL
Compound 4: the middle estimate sits 1.4-fold (0.13 log units) below what was measured, and the stated range covers the measured number.
By their numbers in this assay, from the lowest: compounds 2 and 3 (each within the scatter of the next); then compounds 1 and 4 (each within the scatter of the next).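

In this assay, pyridin-3-yl in place of pyridin-2-yl on a saturated chain carbon bound to an aromatic carbon gives no change at the digits printed from compound 1 to compound 4 (within the scatter) and is the only step shown that isolates a single change. Going by these compounds alone, at this position, the two pyridine attachments are therefore indistinguishable on this read-out, which the earlier compounds could not show. Nothing available explains this result.

Still open, as far as these compounds go, is whether this position stays as forgiving with pyridin-4-yl or an unsubstituted phenyl ring. A basic amine on the ring is equally untested here.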